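The source may report more compounds than this note shows. Statements on the series, on what has been measured and on what is new or still open speak of the compounds shown alone.

In an ADME assay on MDBK cells (Bos taurus) for cytotoxicity (on this read-out lower numbers stand for higher toxicity in this test and higher numbers for lower toxicity in this test), compound 1 `Cc1cccc(Cn2ccc3nc(-c4ccccc4)nc-3c2)c1` gives > 100000 nM, which is a limit of the assay and not a number. Going by the values given here, compound 2 `Brc1cccc(Cn2ccc3nc(-c4ccccc4)nc-3c2)c1`, which carries bromo in place of methyl on an aromatic carbon, gives 85000 nM, the only true number so far, so it cannot yet be ranked against another measured value. Compound 3 `FC(F)(F)c1cccc(Cn2ccc3nc(-c4ccccc4)nc-3c2)c1` keeps the shared core and has trifluoromethyl in place of bromo on an aromatic carbon, meta to a large group: trifluoromethyl in place of bromo on an aromatic carbon. Among the compounds with values here, only one measured step bears on this change, a replacement on the same aromatic carbon: an at least 1.1-fold lower number from compound 1 to compound 2 (0.07 log units; that floor lies within the scatter). That step has one end at a limit, so its size is known only from one side: the limit of > 100000 nM in this assay, at which 1 of the 2 values shown sits. On this slender evidence, a change beyond the scatter is not expected in this assay, and no direction can be favoured. The expected size of the change is small: a 1.1-fold higher number from compound 2 to compound 3 (0.02 log units; within the scatter). For compound 3 the estimated value is 90000 nM, with an expected range of 45000 nM to 100000 nM.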

Compound 3, half-maximal cytotoxic concentration: 98000 nM
Compound 3: middle estimate off by 1.1-fold (0.04 log units), on the low side; measured number inside the range.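

In this assay, trifluoromethyl in place of bromo on an aromatic carbon, meta to a large group, gives a 1.2-fold higher number from compound 2 to compound 3 (0.06 log units; within the scatter). Going by these compounds alone, this is the first step at this position with a true number at both ends, and it shows that replacing bromo, with 1 heavy atom, by trifluoromethyl, with 4 heavy atoms, leaves the read-out within the scatter. The comparison with methyl can be read from one side only, as an at least 1.0-fold lower number from compound 1 to compound 3 (0.00 log units; that floor lies within the scatter), and the value of compound 1, > 100000 nM, is a limit of the assay and not a number, so the size of that step stays unknown: the limit of > 100000 nM in this assay, at which 1 of the 3 values shown sits.

The compounds shown leave open whether a group of another kind on this aromatic carbon, such as an amine, a carboxylic acid or a longer chain, would move the number beyond the scatter in this assay. They also leave open whether bromo or trifluoromethyl would behave in the same way on another carbon of this six-membered aromatic ring or with a different shared core.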